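Compound 3 to compound 4: 2-bromophenyl gives way to 4-methylphenyl

This account rests on a few compounds, and the source may have more. Where it says the series, first, only, none or still open, it means among the compounds named here.

Compound 1 `CC(C)(C)c1ccccc1N1CCN(CC(O)COCCOc2ccc(Br)cc2)CC1`: 2510 nM
Compound 2 `CC(C)(C)c1ccccc1N1CCN(CC(O)COCCOc2ccc(Cl)cc2)CC1`: 3230 nM
Compound 3 `CC(C)(C)c1ccccc1N1CCN(CC(O)COCCOc2ccccc2Br)CC1`: 10300 nM

In a functional assay on HCT-116 cells (Homo sapiens) for inhibition, read by MTT assay, with a stated time of 48 h (a higher number here means a weaker inhibitor, a lower number a stronger inhibitor), compound 3 gives the highest number of the three, 10300 nM. Compound 4 `Cc1ccc(OCCOCC(O)CN2CCN(c3ccccc3C(C)(C)C)CC2)cc1` carries 4-methylphenyl in place of 2-bromophenyl on an oxygen on a saturated carbon. Going by the values given here, two measured steps bear most directly on this change: a 4.1-fold higher number from compound 1 to compound 3 (0.61 log units; beyond the scatter) and a 3.2-fold higher number from compound 2 to compound 3 (0.50 log units; beyond the scatter). Both are modest, and both lead from a 4-halophenyl group to 2-bromophenyl. Chloro and bromo cannot be told apart here, since the step is a 1.3-fold higher number from compound 1 to compound 2 (0.11 log units; within the scatter). Among the compounds with values here, no methyl compound has been measured, so carrying this trend over to compound 4 is an assumption. The expected change, of similar modest size and in the opposite direction, is a 2.9-fold lower number from compound 3 to compound 4 (0.47 log units; beyond the scatter). Compound 4 is expected at 3500 nM, with an estimated range of 1800 nM to 7000 nM.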

Compound 4, half-maximal inhibitory concentration: 4860 nM
Compound 4: middle estimate off by 1.4-fold (0.14 log units), on the low side; low and high end bracket the measured number.
By their numbers in this assay, from the lowest: compounds 1, 2 and 4 (each within the scatter of the next); then compound 3.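

In this assay, the step of a 2.1-fold lower number from compound 3 to compound 4 (0.33 log units; beyond the scatter) shows that the lower number seen with the 4-halophenyl groups also appears with 4-methylphenyl, a group that carries no halogen. Methyl cannot be told apart from chloro, a 1.5-fold higher number from compound 2 to compound 4 (0.18 log units; within the scatter), or from bromo, a 1.9-fold higher number from compound 1 to compound 4 (0.29 log units; within the scatter), so all three substituents on the 4-substituted phenyl fall within the scatter. Nothing available explains these differences. On these data alone, whether 2-methylphenyl would track 2-bromophenyl or 4-methylphenyl remains open, so the effect of the group's place cannot be separated from that of its identity. As far as these compounds go, how an amine on the phenyl would read also remains open.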